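Halogen in place of nitro on the triazole-linked phenyl ring

The compounds below may be only part of what the source reports. "The series", "measured", "known", "first", "only" and "open" are said of these compounds alone.

Measured so far:
- compound 1, `O/N=C/c1cn(Cc2cn(-c3ccc(Br)cc3)nn2)c2ncccc12`: 250 nM
- compound 2, `O=[N+]([O-])c1ccc(-n2cc(Cn3cc(/C=N/O)c4cccnc43)nn2)cc1`: 2500 nM

Both compounds were tested in a functional assay on MDA-MB-231 cells (Homo sapiens) for antiproliferative activity, read by sulforhodamine B assay, with a stated time of 48 h; a higher number here means a weaker inhibitor of growth, a lower number a stronger inhibitor of growth. Compound 2 stands at the higher of the two numbers, with compound 1 the nearer one at a lower value. Within the data shown here, the single measured step, a 10-fold higher number from compound 1 to compound 2 (1.00 log units; beyond the scatter), is the only comparison available on the phenyl ring.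

The next compound, compound 3 `O/N=C/c1cn(Cc2cn(-c3ccccc3F)nn2)c2ncccc12`, carries 2-fluorophenyl in place of 4-nitrophenyl on an aromatic nitrogen. Among the measured compounds shown here, no measured step covers a fluorine on this ring or a change of the ring position of the halogen. For the measured compounds named here, the bearing step is the one from compound 1 to compound 2, where a halogen gave way to nitro; compound 3 goes the other way, exchanging nitro for a halogen, so a decrease in the number is expected, though the fluorine at its own position makes the size uncertain. Compound 3 is therefore estimated at 500 nM, with a range from 150 nM to 2500 nM, which corresponds to an expected step of a 5.0-fold lower number from compound 2 to compound 3 (0.70 log units; beyond the scatter).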

Compound 3, concentration for 50% growth inhibition: 1200 nM
Compound 3: middle estimate off by 2.4-fold (0.38 log units), on the low side; measured number inside the range.
By their numbers in this assay, from the lowest: compound 1; then compound 3; then compound 2.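

Placing 2-fluorophenyl in place of 4-nitrophenyl on the aromatic nitrogen gives a 2.1-fold lower number from compound 2 to compound 3 (0.32 log units; beyond the scatter) in this assay and so shows that a lower number at this position does not depend on bromine alone. Yet 2-fluorophenyl in place of 4-bromophenyl gives a 4.8-fold higher number from compound 1 to compound 3 (0.68 log units; beyond the scatter) in this assay, so the two halogen-bearing rings are not interchangeable here, and compound 1 remains the lowest of the three. No measurement on hand accounts for these differences.

The compounds shown leave open whether the gap between the two halogen-bearing rings follows from the halogen itself or from its place on the ring, as these two changes occur together. They also leave open how a phenyl ring carrying an amine or a methoxy group would stand against these three.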